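The source may hold more compounds than are shown below. What is called first, only, known or untested is meant among the compounds shown, and "the series" means these compounds.

Compound 1 `CCCCCNc1nc(N)c2nc(O)n(Cc3ccccc3)c2n1` carries the lowest of the two numbers in a functional assay (spleen, spleen) for activation, with Mus musculus as the target; a lower number here means that less compound is needed, a higher number that more compound is needed for the effect; there compound 1 gives 0.1 uM. Compound 3 `Cc1ccc(Cn2c(O)nc3c(N)ncnc32)cc1` is the nearest measured neighbour, and in this assay compound 3 gives 10 uM, a gap well beyond the scatter. Compound 2 `Nc1ncnc2c1nc(O)n2C1CCCC1` reaches only a limit of the assay, giving > 10 uM in this assay (the limit of > 10 uM in this assay, at which 1 of the 3 values shown sits). Compound 4 `CCCCNc1nc(N)c2nc(O)n(Cc3ccccc3)c2n1` is not yet measured; it differs from compound 1 by hydrogen in place of methyl on a saturated chain carbon, four bonds along the chain from a nitrogen on an aromatic ring. Going by the values given here, the shared core is otherwise unchanged, and no measured pair isolates this change, so only a small step is expected: a 2.0-fold higher number from compound 1 to compound 4 (0.30 log units; within the scatter) in this assay, probably toward a slightly higher number, within or close to the scatter. Compound 4 is therefore estimated at 0.2 uM in this assay, expected to fall between 0.05 uM and 1 uM.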

Compound 4, minimum effective concentration: 1 uM
Compound 4: middle estimate off by 5.0-fold (0.70 log units), on the low side; the range from low to high includes it.
By their numbers in this assay, from the lowest: compound 1; then compound 4; then compound 3.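

Hydrogen in place of methyl on a saturated chain carbon, four bonds along the chain from a nitrogen on an aromatic ring, gives a 10-fold higher number from compound 1 to compound 4 (1.00 log units; beyond the scatter) in this assay, so this position responds to the loss of a single carbon. The earlier compounds shown here differ in more than one place and could not isolate any such change. Nothing in the data given accounts for the size of this step.

The compounds shown leave open how a longer chain, such as hexyl, or an amine at the chain end would read in this assay. A single step also leaves open whether the number keeps rising as the chain shortens.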